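The compounds below may be only part of what the source reports. "The series", "measured", "known", "first", "only" and "open" are said of these compounds alone.

Compound 1 `Cc1cc(C)c(S(C)(=O)=O)cc1C(=O)N=C(N)N` gives 11 nM in a functional assay for inhibition of sodium/hydrogen exchanger (Oryctolagus cuniculus); on this read-out higher numbers stand for weaker inhibition and lower numbers for stronger inhibition. Among the compounds with values here, compound 2 `Cc1cc(-c2cc(Cl)cc(Cl)c2)c(S(C)(=O)=O)cc1C(=O)N=C(N)N` gives 130 nM and thus holds the highest of the two numbers measured so far, with compound 1 the only other, reached through a 12-fold higher number from compound 1 to compound 2 (1.07 log units; beyond the scatter). Compound 3 `Cc1cc(-c2ccco2)c(S(C)(=O)=O)cc1C(=O)N=C(N)N` takes one further step: furan-2-yl in place of 3,5-dichlorophenyl on an aromatic carbon. Within the data shown here, the single measured step, which put an aromatic ring in place of a methyl, weakened inhibition greatly. Compound 3 keeps an aromatic ring at that position, but one with fewer heavy atoms, so a number between those of compound 1 and compound 2 is expected. The expected step is therefore a 2.6-fold lower number from compound 2 to compound 3 (0.41 log units; beyond the scatter). Compound 3 is estimated at 50 nM, within 15 nM to 170 nM.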

Compound 3, half-maximal inhibitory concentration: 16 nM
For compound 3 the middle estimate is 3.1-fold (0.49 log units) above the measured one, and the stated range covers the measured number.
By their numbers in this assay, from the lowest: compounds 1 and 3 (each within the scatter of the next); then compound 2.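

An aromatic ring at this position does not by itself weaken inhibition: furan-2-yl in place of 3,5-dichlorophenyl gives an 8.1-fold lower number from compound 2 to compound 3 (0.91 log units; beyond the scatter) and so recovers most of the earlier loss. Against methyl, furan-2-yl gives a 1.5-fold higher number from compound 1 to compound 3 (0.16 log units; within the scatter) and so cannot be told apart from it, which ties the loss to 3,5-dichlorophenyl, not to every ring here. Nothing available explains the difference between these two rings.

Going by these compounds, compound 2 and compound 3 differ in ring size, ring atoms and chlorines at once, so the part responsible stays open. A plain phenyl or a phenyl carrying a single chlorine could help separate these features.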